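A few compounds are considered here, and "the series" means these few. Any claim that something is new, unique, unknown or untested is made for them only; others in the source may bear on it.

Compound 1 `CCCCCCCCOc1nc(N)nc2c1ncn2/C=C1/CC1(CO)CO`: in an ADME assay on CCRF-HSB-2 cells (Homo sapiens) for cytotoxicity, with a stated time of 7 days (a higher number here means that more compound is tolerated, a lower number that less compound is tolerated), compound 1 gives > 20000 nM, a limit of the assay rather than a number.
Compound 2 `CC(C)Nc1nc(N)nc2c1ncn2/C=C1/CC1(CO)CO`: in this assay compound 2 gives > 20000 nM, again a limit.
Compound 3 `Nc1nc(NC2CC2)c2ncn(/C=C3/CC3(CO)CO)c2n1`: in this assay compound 3 gives > 20000 nM, again a limit.

Within the data shown here, compound 3 thus stands where every value so far stands, at the limit of > 20000 nM in this assay, at which 3 of the 3 values shown sit. The measured steps that touch the same aromatic carbon, a step that the two limits leave unreadable from compound 1 to compound 2, a step that the two limits leave unreadable from compound 1 to compound 3 and a step that the two limits leave unreadable from compound 2 to compound 3, are all of unreadable size, so neither direction nor magnitude can be taken from them. Compound 4 `CCCCSc1nc(N)nc2c1ncn2/C=C1/CC1(CO)CO` differs from compound 3 by butylsulfanyl in place of cyclopropylamino on an aromatic carbon. Among the measured compounds shown here, none of the measured steps brings in butylsulfanyl, so the expectation rests only on the shared limit: compound 4 is expected to remain at that limit, an expected step that the limit leaves unreadable from compound 3 to compound 4. The estimate for compound 4 is 25000 nM, with a range from 8000 nM to 80000 nM.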

Compound 4, half-maximal cytotoxic concentration: 89000 nM
The estimate for compound 4 lay 3.6-fold (0.55 log units) below the measured number, and the stated range ends below it.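

No step to compound 4 can be read from compound 1, compound 2 or compound 3, each of which gives only a limit: the limit of > 20000 nM in this assay, at which 3 of the 4 values shown sit.

The compounds shown leave open whether butylsulfanyl, compared with the other groups on that aromatic carbon, shifts tolerance at all in this assay.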